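Adding a Benzyloxy Group to a Weak Cell Inhibitor

The source may hold more compounds than are shown below. What is called first, only, known or untested is meant among the compounds shown, and "the series" means these compounds.

Compound 1, `O=c1c(Cc2coc3cccc(OCC4CCCCC4)c3c2=O)coc2cc(Cl)ccc12`: > 10000 nM
Compound 2, `CC(C)CCOc1cccc2occ(Cc3coc4ccccc4c3=O)c(=O)c12`: > 10000 nM
Compound 3, `O=c1c(Cc2coc3ccccc3c2=O)coc2ccccc12`: 7770 nM

All three were tested in a functional assay on NUGC-3 cells (Homo sapiens) for antiproliferative activity, read by XTT assay; a lower number here means a stronger inhibitor, a higher number a weaker inhibitor. For compound 1 the value of > 10000 nM is a limit of the assay, not a number. For compound 2 the value of > 10000 nM is likewise a limit. Compound 3 gives 7770 nM and is therefore the only one of the three with a measured number, which is what the limit of > 10000 nM in this assay, at which 2 of the 3 values shown sit, describes. Going by the values given here, only one pair differs in a single place, compound 2 and compound 3: an at least 1.2-fold lower number from compound 2 to compound 3 (0.10 log units; that floor lies within the scatter), compound 2 carrying an isopentyloxy group where compound 3 carries a hydrogen.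

Compound 4, `O=c1c(Cc2coc3cccc(OCc4ccccc4)c3c2=O)coc2ccccc12`, has not yet been measured. It differs from compound 3 by benzyloxy in place of hydrogen on an aromatic carbon. The step from compound 2 to compound 3 is the one that bears on it: removing an alkoxy group from an aromatic carbon there gave at most a small gain, inside the scatter. Putting a benzyloxy group onto compound 3 is therefore expected to give no gain and possibly a number back toward the limit. In this assay compound 4 is estimated at 12000 nM, between 5000 nM and 30000 nM. The expected change is a 1.5-fold higher number from compound 3 to compound 4 (0.19 log units; within the scatter).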

Compound 4, half-maximal inhibitory concentration: 7220 nM
For compound 4 the middle estimate is 1.7-fold (0.22 log units) above the measured one; the measured number falls inside the stated range.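

Both ends of the new step are measured numbers, so this position on the shared core is now shown to carry a benzyloxy group, with its added six-membered aromatic ring of carbon only, and the size of the change can be read: a 1.1-fold lower number from compound 3 to compound 4 (0.03 log units; within the scatter). Where the oxygen-bound chain ends in phenyl in place of isobutyl, only a floor can be given, and it does not clear the scatter: an at least 1.3-fold lower number from compound 2 to compound 4 (0.14 log units; that floor lies within the scatter). The value of compound 2 is a limit of the assay and not a number, and the same is true of compound 1: the limit of > 10000 nM in this assay, at which 2 of the 4 values shown sit.

As far as these compounds go, it remains open whether any group at this position moves the number beyond the scatter. An amine or a carboxylic acid in place of the benzyloxy group would put that question to a different kind of substituent.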